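Core aryl swap in a quinoline permeability series

The source may hold more compounds than are shown below. What is called first, only, known or untested is meant among the compounds shown, and "the series" means these compounds.

Measured so far in an ADME assay for permeability, using PAMPA, with a stated time of 30 min, at pH 7.4; on this read-out higher numbers stand for higher permeability and lower numbers for lower permeability:
compound 1 `COc1cccc(CNCCCNc2ccnc3cc(-c4ccc(F)cc4)ccc23)c1O`, 237 10^-6 cm/s
compound 2 `c1ccc(Cc2ccc3c(NCCCNCc4ccco4)ccnc3c2)cc1`, 23 10^-6 cm/s
compound 3 `COc1ccc(Oc2ccc3c(NCCCNCc4cccc(OC)c4O)ccnc3c2)cc1`, 317 10^-6 cm/s

Compound 3 gives the highest of the three numbers, though compound 1 sits within the scatter of it and only compound 2 lies clearly lower. The next compound is compound 4 `COc1cccc(CNCCCNc2ccnc3cc(Cc4ccccc4)ccc23)c1O`, which differs from compound 3 by benzyl in place of 4-methoxyphenoxy on an aromatic carbon.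

For the measured compounds named here, only one measured step touches this position: a 1.3-fold higher number from compound 1 to compound 3 (0.13 log units; within the scatter). That swap left this assay unchanged within the scatter. Compound 2 also carries the benzyl group on the core but differs from compound 4 elsewhere, so its low value bears only loosely on it. Compound 4 is therefore expected to stay close to compound 3, with a modest downward lean from compound 2, giving an expected step of a 2.1-fold lower number from compound 3 to compound 4 (0.32 log units; beyond the scatter). The estimate for compound 4 is 150 10^-6 cm/s, with a range from 40 10^-6 cm/s to 400 10^-6 cm/s.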

Compound 4, apparent permeability: 23 10^-6 cm/s
The estimate for compound 4 lay 6.5-fold (0.81 log units) above the measured number, and the stated range ends above it.
By their numbers in this assay, from the lowest: compounds 2 and 4 (each within the scatter of the next); then compounds 1 and 3 (each within the scatter of the next).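

In this assay this aromatic carbon proves sensitive to the choice of group: benzyl in place of 4-methoxyphenoxy gives a large step (a 14-fold lower number from compound 3 to compound 4 (1.14 log units; beyond the scatter)), and benzyl in place of 4-fluorophenyl gives another (a 10-fold lower number from compound 1 to compound 4 (1.01 log units; beyond the scatter)). For the compounds shown here, with benzyl held on the core, 2-hydroxy-3-methoxyphenyl in place of furan-2-yl on the saturated chain carbon shows no step (no change at the digits printed from compound 2 to compound 4 (within the scatter)). Nothing measured on these compounds accounts for the fall with benzyl. Open, on these data alone, is whether a 4-methoxybenzyl or phenylamino group on this aromatic carbon would stay with compound 1 and compound 3 or with compound 4.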